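Swapping the aminopyridine for an aminopyrimidine in compound 1

A few compounds are considered here, and "the series" means these few. Any claim that something is new, unique, unknown or untested is made for them only; others in the source may bear on it.

Measured compounds:
Compound 1 `Cc1cc(C(F)(F)F)cc(NC[C@@H]2CC3(CC3)CN2C(=O)c2nc(C)sc2-c2ccccc2)n1` gives 7.8 in a functional assay on CHO cells for antagonist activity at Orexin/Hypocretin receptor type 1 (Homo sapiens), read by FLIPR and calcium flux; a higher number here means a more potent compound, by a factor of ten per unit of this negative logarithm, a lower number a less potent compound.
Compound 2 `Cc1ccc(-c2ncccn2)c(C(=O)N2CC3(CC3)C[C@H]2CNc2ccc(C(F)(F)F)cn2)n1` gives 8.4 in this assay.
Compound 3 `O=C(c1ncccc1-c1ncccn1)N1CC2(CC2)C[C@H]1CNc1ccc(C(F)(F)F)cn1` gives 7.7 in this assay.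

Among these three, compound 1 stands second, with compound 3 within the scatter of it and compound 2 beyond it. Within the data shown here, the only single-point step, a number 0.70 log units lower from compound 2 to compound 3 (beyond the scatter), concerns a methyl on the aromatic ring of the acyl side and does not touch the amine side changed here. Compound 4 `Cc1ccnc(NC[C@@H]2CC3(CC3)CN2C(=O)c2nc(C)sc2-c2ccccc2)n1` differs from compound 1 by 4-methylpyrimidin-2-yl in place of 6-methyl-4-(trifluoromethyl)pyridin-2-yl on an amine nitrogen. Among the measured compounds shown here, no measured step bears on this change, so the expectation rests on compound 1 alone, and a modest loss in this assay is estimated, a number 0.50 log units lower from compound 1 to compound 4 (beyond the scatter). Compound 4 is thus expected to give about 7.3, within 6.5 to 8.1.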

Compound 4, negative logarithm of the antagonist equilibrium constant: 6.1
The estimate for compound 4 lay 1.20 log units above the measured number; measured number outside the range, below it.
By their numbers in this assay, from the lowest: compound 4; then compounds 3 and 1 (each within the scatter of the next); then compound 2.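

In this assay, among these compounds, the group on the amine nitrogen matters a great deal: the step is a number 1.70 log units lower from compound 1 to compound 4 (beyond the scatter) and is large, whereas the only earlier step concerned the acyl side. This single exchange alters the ring hetero atoms and removes the trifluoromethyl group together, so the two changes cannot be separated here. Nothing at hand explains the loss. From the compounds shown here alone, whether the drop follows the second ring nitrogen or the missing trifluoromethyl remains open. A 4-(trifluoromethyl)pyrimidin-2-yl group on the same amine nitrogen would bear directly on that question.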